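Working notes: from compound 2 to compound 3

The source may hold more compounds than are shown below. What is called first, only, known or untested is meant among the compounds shown, and "the series" means these compounds.

- compound 1 `COc1cc(NC(C)CCCNC(=O)NC2CCCCC2)c2ncccc2c1`: "not determined" (no result reported)
- compound 2 `COc1cc(NC(C)CCCNC(=O)NNC(=O)/C=C/c2ccc(C(F)(F)F)cc2)c2ncccc2c1`: 28300 nM

In an ADME assay on L6 cells (Rattus norvegicus) for cytotoxicity, read by resazurin assay, with a stated time of 70 h (a lower number here means a stronger inhibitor, a higher number a weaker inhibitor), compound 2 gives 28300 nM. Going by the values given here, this is the only number, so compound 2 cannot yet be ranked against another compound. Compound 3 `COc1cc(NC(C)CCCNC(=O)NNC(=O)N(CCO)CCO)c2ncccc2c1` is unmeasured. It carries bis(2-hydroxyethyl)amino in place of 2-(4-(trifluoromethyl)phenyl)ethenyl on a carbonyl carbon. Among the compounds with values here, no measured step exists to calibrate this change, so the expectation is tentative. In this assay a shift beyond the scatter towards a higher number, meaning a weaker inhibitor, is expected. The estimated change is a 2.8-fold higher number from compound 2 to compound 3 (0.45 log units; beyond the scatter). For compound 3 the expected value is 80000 nM, with an estimated range of 25000 nM to 250000 nM.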

Compound 3, half-maximal inhibitory concentration: 178000 nM
The estimate for compound 3 lay 2.2-fold (0.35 log units) below the measured number; measured number inside the range.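

In this assay the place on the carbonyl carbon now has its first measured step: bis(2-hydroxyethyl)amino in place of 2-(4-(trifluoromethyl)phenyl)ethenyl gives a 6.3-fold higher number from compound 2 to compound 3 (0.80 log units; beyond the scatter) and shows that the group here can move the number beyond the scatter. The step swaps an aromatic ring and a double bond for a ringless group with hydrogen-bond donors, and it cannot separate these features. Nothing available explains the shift. Open, on these data alone, is whether diethylamino, which has no hydroxyl groups, would give a similar number at this carbonyl carbon.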